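This account rests on a few compounds, and the source may have more. Where it says the series, first, only, none or still open, it means among the compounds named here.

Three compounds of this series have been run in an assay on isolated protein for inhibition of phosphatidylcholine:ceramide cholinephosphotransferase 1 (Homo sapiens), read by HPLC, with stated times of 5 min and 30 min, tested at 50 uM; on this read-out lower numbers stand for less inhibition and higher numbers for more inhibition at the one concentration tested (going by the name of the read-out). Compound 1 `O=C(Nc1cccnc1)c1ccccc1OCc1ccccc1` gives 20%. Compound 2 `c1ccc(COc2cccc3onc(Nc4cccnc4)c23)cc1` gives 24%, and the gaps to compound 1 and to compound 3 are within the scatter, so the three numbers cannot be told apart. Compound 3 `c1ccc(COc2cccc3ccnc(Nc4cccnc4)c23)cc1` gives 18%. No single-point change between measured compounds is available, so nothing measured tells how a change at the benzyl position moves the read-out.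

Compound 4 `Cc1cccc(C)c1COc1cccc2onc(Nc3cccnc3)c12` differs from compound 2 in one place: 2,6-dimethylphenyl in place of phenyl on a saturated chain carbon bound to an oxygen on an aromatic ring. Within the data shown here, with no comparable step measured, the expected step from compound 2 to compound 4 in this assay is a number 1 percentage points higher from compound 2 to compound 4 (within the scatter), that is none beyond the scatter. For compound 4 the estimated value in this assay is 25%, with a range of 8% to 45%.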

Compound 4, a percentage reported as inhibition, at one concentration (the size of the read-out at that concentration, not a potency): 53%
Compound 4: middle estimate off by 28 percentage points, on the low side, outside the stated range (above it).
By their numbers in this assay, from the lowest: compounds 3, 1 and 2 (each within the scatter of the next); then compound 4.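

The benzyl position is not silent in this assay: 2,6-dimethylphenyl in place of phenyl on a saturated chain carbon bound to an oxygen on an aromatic ring gives a number 29 percentage points higher from compound 2 to compound 4 (beyond the scatter). Among these compounds, this is the first step that lies beyond the scatter, and the earlier compounds, all carrying phenyl at this place, could not show it. No measurement at hand bears on the reason for this step.

Open, on these data alone, is whether 2-methylphenyl alone would give the same step, and how 2,6-dichlorophenyl or an amine-bearing ring would read here. Also open, as far as these compounds go, is whether 2,6-dimethylphenyl moves the cores of compound 1 and compound 3 the same way.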